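Chloro to sulfanyl on the shared core, compound 1 to compound 4

This account rests on a few compounds, and the source may have more. Where it says the series, first, only, none or still open, it means among the compounds named here.

Compound 1 `Nc1ncnc2c1nc(Cl)n2Cc1ccccc1` is read in a functional assay (spleen, spleen) for activation, with Mus musculus as the target; on this read-out lower numbers stand for an effect already at smaller amounts and higher numbers for an effect only at larger amounts of compound. In this assay compound 1 gives only a limit of the assay, > 10 uM, so its place among the measured compounds is known solely as the limit of > 10 uM in this assay, at which 1 of the 3 values shown sits. Two related compounds carry a number. Compound 2 `CCSc1nc(N)c2nc(O)n(Cc3ccccc3)c2n1` gives 0.1 uM in this assay. Compound 3 `COc1ccccc1Cn1c(O)nc2c(N)ncnc21` gives 10 uM in this assay. Going by the values given here, both of these differ from compound 1 at more than one place, so no single step between measured compounds is available, and nothing measured isolates the change at the chloro.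

Compound 4 `Nc1ncnc2c1nc(S)n2Cc1ccccc1` differs from compound 1 in one place: sulfanyl in place of chloro on an aromatic carbon. Because compound 1 stands at the limit of > 10 uM in this assay, at which 1 of the 3 values shown sits, the direction of the step can only be toward a number or toward a second limit. The expectation is a moderate step toward an effect at smaller amounts, with the chance of another limit kept in view. Compound 4 is estimated at 10 uM in this assay, within 2 uM to 30 uM. The expected step is a number no higher from compound 1 to compound 4 (the limit leaves the size open).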

Compound 4, minimum effective concentration: 10 uM
Beside the measured number, compound 4's estimate shows no gap at the digits printed, within the range that was stated.
By their numbers in this assay, from the lowest: compound 2; then compounds 3 and 4 (each within the scatter of the next).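

In this assay, going by these compounds alone, sulfanyl in place of chloro on this aromatic carbon gives the first single-place step: a number no higher from compound 1 to compound 4 (the limit leaves the size open). Compound 1 gives > 10 uM, which is a limit of the assay. With sulfanyl at this position the read-out becomes a number, but the size of the step cannot be read because compound 1 stands at a limit: the limit of > 10 uM in this assay, at which 1 of the 4 values shown sits.

The compounds shown leave open how an amine or a butylsulfanyl chain on this same carbon would read in this assay. Within the data shown here, they also leave open whether the change from chloro to sulfanyl would carry over to the other substitution patterns, since no single-place step ties compound 4 to compound 2 or compound 3.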